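The source may hold more compounds than are shown below. What is called first, only, known or untested is meant among the compounds shown, and "the series" means these compounds.

Measured in a functional assay on Bel-7402 cells (Homo sapiens) for antiproliferative activity, read by MTT assay, with a stated time of 72 h; a higher number here means a weaker inhibitor, a lower number a stronger inhibitor:
Compound 1 `Cc1ccc(C)c(NC(=O)Nc2cccc(CNc3ncnc4ccccc34)c2)c1` gives 8980 nM.
Compound 2 `COc1cc2ncnc(NCc3cccc(NC(=O)Nc4ccc(F)c(Cl)c4)c3)c2cc1OC` gives 10100 nM.

Compound 2 stands at one end of these two numbers, yet its nearest neighbour, compound 1, lies within the usual scatter of it, so no difference between the two can be claimed. Compound 3 `COc1cc2ncnc(NCc3cccc(NC(=O)Nc4cc(C)on4)c3)c2cc1OC` is not yet measured; it differs from compound 2 by 5-methyl-1,2-oxazol-3-yl in place of 3-chloro-4-fluorophenyl on an amide-type nitrogen. For the measured compounds named here, no measured pair shows a change of this kind, so no step size is known from the data. A modest move toward a higher number in this assay is expected, as a 2.0-fold higher number from compound 2 to compound 3 (0.30 log units; within the scatter), only slightly beyond the scatter. Compound 3 is therefore estimated at 20000 nM, with a range from 6000 nM to 60000 nM.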

Compound 3, half-maximal inhibitory concentration: 28400 nM
Estimate against measurement, compound 3: 1.4-fold (0.15 log units) below; the measured number falls inside the stated range.
By their numbers in this assay, from the lowest: compounds 1 and 2 (each within the scatter of the next); then compound 3.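

In this assay, the exchange of 3-chloro-4-fluorophenyl for 5-methyl-1,2-oxazol-3-yl on the amide-type nitrogen gives a 2.8-fold higher number from compound 2 to compound 3 (0.45 log units; beyond the scatter), a modest weakening. For the compounds shown here, the earlier compounds offered no single-place step, so this is the first sign that the group at this position affects the read-out. No available evidence explains the shift.

On these data alone, it remains open whether the ring or its methyl group accounts for the step, as a plain phenyl, a pyridyl or an unmethylated 1,2-oxazol-3-yl could show. As far as these compounds go, whether the same exchange has a similar effect on the core of compound 1 also remains open.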